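Pyridine Substituent Change on a Thiazole Acetic Acid Series

The compounds below may be only part of what the source reports. "The series", "measured", "known", "first", "only" and "open" are said of these compounds alone.

Compound 1 `O=C(O)Cc1sc(C(c2ccc(F)cc2)c2ccc(F)cc2)nc1-c1ccnc(Cl)c1` and compound 2 `Cc1cc(-c2nc(C(c3ccc(F)cc3)c3ccc(F)cc3)sc2CC(=O)O)ccn1` share one core and differ only in the group on the pyridine ring. In an in vitro assay on HEK385-7 cells for displacement of a labelled ligand from prostaglandin D2 receptor 2 (Homo sapiens) (on this read-out higher numbers stand for weaker inhibition and lower numbers for stronger inhibition), compound 1 gives 3.1 nM and compound 2 gives 3.1 nM, so compound 2 stands level with compound 1, and the step of no change at the digits printed from compound 1 to compound 2 (within the scatter) lies within the scatter. Compound 3 `Nc1cc(-c2nc(C(c3ccc(F)cc3)c3ccc(F)cc3)sc2CC(=O)O)cc(F)n1` carries a further variation at the same place: 2-amino-6-fluoropyridin-4-yl in place of 2-methylpyridin-4-yl on an aromatic carbon. Among the measured compounds shown here, the only measured step that bears on this, from compound 1 to compound 2, changed nothing beyond the scatter, which suggests that this position accepts different groups, though that rests on a single pair and the entering group differs more in kind. The account therefore expects compound 3 to show a step of a 1.6-fold higher number from compound 2 to compound 3 (0.21 log units; within the scatter), essentially no change beyond the scatter or at most a modest loss. The estimate for compound 3 in this assay is 5 nM, in a range from 1.5 nM to 20 nM.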

Compound 3, half-maximal inhibitory concentration: 220 nM
Estimate against measurement, compound 3: 44-fold (1.64 log units) below, and the stated range ends below it.
By their numbers in this assay, from the lowest: compounds 1 and 2 (each within the scatter of the next); then compound 3.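

In this assay, the position on the shared core that held 2-chloropyridin-4-yl and 2-methylpyridin-4-yl without any difference does not accept every substituted pyridine: putting 2-amino-6-fluoropyridin-4-yl there gives a 71-fold higher number from compound 2 to compound 3 (1.85 log units; beyond the scatter), and the same group in place of 2-chloropyridin-4-yl gives a 71-fold higher number from compound 1 to compound 3 (1.85 log units; beyond the scatter). The freedom suggested by the chloro and methyl pair therefore stops short of this group, and the two steps agree in size and direction whichever of the two earlier compounds is taken as the start. Nothing here gives a reason for the loss.

The entering group brings an amino group and a fluorine together, so the compounds shown do not separate the two. A 2-aminopyridin-4-yl or a 2-fluoropyridin-4-yl group at this place would show whether one of them alone carries the step.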